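Swapping 4-methoxyphenyl for benzyl on a ring amine

The source may report more compounds than this note shows. Statements on the series, on what has been measured and on what is new or still open speak of the compounds shown alone.

Compound 1 `Oc1ccc2cc1Oc1ccc(cc1)CCc1ccc(CN3CCCC3)c(O)c1-c1ccc(cc1O)CC2`: 2260 nM
Compound 2 `Oc1ccc2cc1Oc1ccc(cc1)CCc1ccc(CN3CCCCC3)c(O)c1-c1ccc(cc1O)CC2`: 7120 nM
Compound 3 `COc1ccc(N2CCN(Cc3ccc4c(c3O)-c3ccc(cc3O)CCc3ccc(O)c(c3)Oc3ccc(cc3)CC4)CC2)cc1`: > 20000 nM (a limit)

All three compounds were tested in a functional assay on A549 cells (Homo sapiens) for antiproliferative activity, read by MTT assay, with a stated time of 48 h; a higher number here means a weaker inhibitor, a lower number a stronger inhibitor. Compound 3 sits at the limit of > 20000 nM in this assay, at which 1 of the 3 values shown sits, and that is a limit, not a number.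

Compound 4 `Oc1ccc2cc1Oc1ccc(cc1)CCc1ccc(CN3CCN(Cc4ccccc4)CC3)c(O)c1-c1ccc(cc1O)CC2` keeps the core of compound 3 and changes one group: benzyl in place of 4-methoxyphenyl on an amine nitrogen in a ring. In words, this is benzyl in place of 4-methoxyphenyl on an amine nitrogen in a ring.

Among the measured compounds shown here, no measured step covers this exact swap. The nearest evidence is a 3.2-fold higher number from compound 1 to compound 2 (0.50 log units; beyond the scatter), a modest step that lies beyond the scatter and also comes from changing the amine group. It suggests that such changes can move the number by a modest amount. Compound 2 gives 7120 nM, so a number within the range of the assay is plausible for compound 4, and a modest shift towards a lower number is expected. The estimated change is an at least 2.0-fold lower number from compound 3 to compound 4 (0.30 log units; that floor lies within the scatter). Compound 4 is expected to give about 10000 nM, with an estimated range of 3500 nM to 28000 nM.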

Compound 4, half-maximal inhibitory concentration: > 20000 nM
Compound 4 was reported as a limit (the forecaster's own chance of this, stated with the estimate: 30%); middle value at least 2.0-fold (0.30 log units) away from the limit.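

Compound 3 and compound 4 are each reported in this assay only as a limit, not a number, so no step can be read between them: the limit of > 20000 nM in this assay, at which 2 of the 4 values shown sit.

The compounds shown leave open whether benzyl in place of 4-methoxyphenyl on an amine nitrogen in a ring changes the number at all, and in which direction.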